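Shifting the Phenyl Substituent in an Imidazopyrazine Series

This account rests on a few compounds, and the source may have more. Where it says the series, first, only, none or still open, it means among the compounds named here.

Three compounds share a core and differ only in the group on the pendant phenyl ring. Compound 1 `O=Cc1ccc(-c2cn3ccnc3c(-c3ccc4ncn(C5CCCCC5)c4c3)n2)cc1` carries a formyl group and gives 25.3% in a functional assay on NCI-H522 cells (Homo sapiens) for inhibition, read by sulforhodamine B assay, with a stated time of 48 h, tested at 10 uM; a lower number here means less inhibition, a higher number more inhibition at the concentration tested (going by the name of the read-out). Compound 2 `Fc1ccc(-c2cn3ccnc3c(-c3ccc4ncn(C5CCCCC5)c4c3)n2)cc1` carries a fluoro group and gives 15.5%; compound 3 `CC(=O)c1ccc(-c2cn3ccnc3c(-c3ccc4ncn(C5CCCCC5)c4c3)n2)cc1` carries an acetyl group and gives 10.4%. Compound 2 stands second highest of the three numbers: its nearest neighbour is compound 3, and the step of a number 5.1 percentage points lower from compound 2 to compound 3 (within the scatter) lies within the scatter, while the step of a number 9.8 percentage points lower from compound 1 to compound 2 (within the scatter) also lies within the scatter. Within the data shown here, only the step of a number 14.9 percentage points lower from compound 1 to compound 3 (beyond the scatter) reaches beyond it.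

Compound 4 `FC(F)(F)c1cccc(-c2cn3ccnc3c(-c3ccc4ncn(C5CCCCC5)c4c3)n2)c1` is not yet measured. Its change from compound 2 is 3-(trifluoromethyl)phenyl in place of 4-fluorophenyl on an aromatic carbon. The two steps that touch compound 2 both stayed within the scatter, so swapping the substituent on this phenyl ring has so far moved the read-out little. No step beyond the scatter is therefore expected; the step of a number 1.5 percentage points higher from compound 2 to compound 4 (within the scatter) is estimated to be small. Compound 4 is expected to give about 17%, within 2% to 38%.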

Compound 4, a percentage reported as inhibition, at one concentration (the size of the read-out at that concentration, not a potency): 10.7%
Compound 4: the middle estimate sits 6.3 percentage points above what was measured; the measured number falls inside the stated range.
By their numbers in this assay, from the lowest: compounds 3, 4, 2 and 1 (each within the scatter of the next, the first and the last beyond it).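

With 3-(trifluoromethyl)phenyl in place of 4-fluorophenyl, this assay shows a number 4.8 percentage points lower from compound 2 to compound 4 (within the scatter), and with the same group in place of 4-acetylphenyl it shows a number 0.3 percentage points higher from compound 3 to compound 4 (within the scatter), so a larger group with a different substitution pattern in its name still leaves these three compounds within the scatter of one another's neighbours. Against 4-formylphenyl the same group gives a number 14.6 percentage points lower from compound 1 to compound 4 (beyond the scatter), a second step beyond the scatter that starts at compound 1, although compound 1 remains within the scatter of compound 2. Nothing measured here accounts for these numbers.

The compounds shown leave open whether 3-fluorophenyl would read differently from 4-fluorophenyl. They also leave open whether an amine or a carboxylic acid on this phenyl ring would move the read-out beyond the narrow span seen so far.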